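A few compounds are considered here, and "the series" means these few. Any claim that something is new, unique, unknown or untested is made for them only; others in the source may bear on it.

Of the compounds shown here, two have been measured in a functional assay on HEK293 cells for agonist activity at Toll-like receptor 2 (Homo sapiens), read by reporter gene assay, with a stated time of 12 h; on this read-out lower numbers stand for an effect already at smaller amounts and higher numbers for an effect only at larger amounts of compound. Compound 1 `CCCCCCCCCCCCCCCC(=O)OCCSC[C@H](N)C(=O)N[C@@H](CO)C(=O)OC` gives 3.63 nM in this assay. Compound 2 `CCCCCCCCCCCCCCCC(=O)OCCSC[C@H](NC(C)=O)C(=O)N[C@@H](CO)C(=O)OC` carries an acetyl group on the amine nitrogen in place of a hydrogen; in this assay compound 2 gives 1.01 nM. For the measured compounds named here, the only step measured so far is a 3.6-fold lower number from compound 1 to compound 2 (0.56 log units; beyond the scatter). Going by the values given here, compound 2 thus stands at the lowest of the two numbers, with compound 1 as its single neighbour at a higher number.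

Compound 3 `CCCCCCCCCCCCCCCC(=O)OCCSC[C@H](NC(=O)CCC)C(=O)N[C@@H](CO)C(=O)OC` is the next member. It differs from compound 2 by ethyl in place of hydrogen on a saturated chain carbon bound to a carbonyl carbon, so the acetamido group becomes a (propylcarbonyl)amino group. The measured step bears on this change only indirectly: it concerns the same acyl group, but installs it on the nitrogen rather than lengthening it, and it was modest. Among the compounds with values here, no measured pair shows what a longer acyl chain does in this assay. The expectation is therefore a step of a 1.3-fold lower number from compound 2 to compound 3 (0.10 log units; within the scatter), within the scatter. Compound 3 is estimated at 0.8 nM in this assay, with a range from 0.3 nM to 2.5 nM.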

Compound 3, half-maximal effective concentration: 1.64 nM
Compound 3: middle estimate off by 2.1-fold (0.31 log units), on the low side, within the range that was stated.
By their numbers in this assay, from the lowest: compounds 2 and 3 (each within the scatter of the next); then compound 1.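

In this assay, extending the acyl group on the amine nitrogen from acetyl to propylcarbonyl gives a 1.6-fold higher number from compound 2 to compound 3 (0.21 log units; within the scatter), so ethyl in place of hydrogen on this saturated chain carbon bound to a carbonyl carbon leaves the read-out within the scatter. Acylation of the free amine also holds with the extended group, at a 2.2-fold lower number from compound 1 to compound 3 (0.35 log units; beyond the scatter), which means that both acylated compounds now give lower numbers than the free amine, with no compound among the three going against this. The data shown offer no evidence on why the numbers fall as they do.

Going by these compounds, what stays open is how far this acyl position extends: a longer chain, a branched chain or a benzoyl group could stay within the scatter of the acetyl and propylcarbonyl amides or could move clearly away from them. On these data alone, the other end of the shared core also remains untested by these compounds, for example a carboxylic acid or a primary amide in place of the methyl ester, alongside any change of acyl group on the nitrogen.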